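The source may hold more compounds than are shown below. What is called first, only, known or untested is meant among the compounds shown, and "the series" means these compounds.

Measured compounds:
Compound 1 `COc1cc(Oc2cccc(Nc3ccccc3)c2)cc(OC)c1CNCCNC(C)=O` — 11900 nM
Compound 2 `COc1cc(Oc2cccc(Nc3ccccc3)c2)cc(OC)c1CNCc1ccc(C)cc1` — 11800 nM

Both compounds were run in a functional assay on SW-620 cells (Homo sapiens) for inhibition, read by MTT assay, with a stated time of 72 h; a higher number here means a weaker inhibitor, a lower number a stronger inhibitor. In this assay compound 1 gives 11900 nM and compound 2 gives 11800 nM. Compound 2 holds the lower of the two numbers, yet the step of a 1.0-fold lower number from compound 1 to compound 2 (0.00 log units; within the scatter) lies within the scatter, so the two compounds cannot be told apart on potency. That step put 4-methylphenyl in place of acetamidomethyl on a saturated chain carbon bound to an amine nitrogen and left the number where it was.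

Compound 3 `CCN1CCN(Cc2c(OC)cc(Oc3cccc(Nc4ccccc4)c3)cc2OC)CC1` has not yet been measured. It differs from compound 2 by 4-ethylpiperazin-1-yl in place of (4-methylbenzyl)amino on a saturated chain carbon bound to an aromatic carbon. Going by the values given here, the single measured step altered only the group on a saturated chain carbon bound to an amine nitrogen and was flat; in compound 3 the (4-methylbenzyl)amino group itself leaves, so that step bears on the change only loosely, and no measured step covers it directly. Compound 3 is therefore expected to stay near compound 2, with an estimated step of a 1.0-fold higher number from compound 2 to compound 3 (0.01 log units; within the scatter) in this assay, nothing beyond the scatter. Compound 3 is estimated at 12000 nM, with a range from 4000 nM to 40000 nM.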

Compound 3, half-maximal inhibitory concentration: > 20000 nM
Compound 3: no number, only a limit; the forecaster's own chance of this, stated with the estimate: 15%; at least 1.6-fold (0.22 log units) between middle value and limit.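

In this assay compound 3 gives no number, only a limit: the limit of > 20000 nM in this assay, at which 1 of the 3 values shown sits.

The earlier pair altered only the group on a saturated chain carbon bound to an amine nitrogen, whereas here the whole amino group on a saturated chain carbon bound to an aromatic carbon is exchanged: 4-ethylpiperazin-1-yl in place of (4-methylbenzyl)amino gives an at least 1.6-fold higher number from compound 2 to compound 3 (0.22 log units; that floor lies within the scatter), and the same group in place of (2-acetamidoethyl)amino gives an at least 1.6-fold higher number from compound 1 to compound 3 (0.22 log units; that floor lies within the scatter). Going by these compounds alone, both floors lie within the scatter, so the result shows only that this exchange, which takes the count of hydrogen-bond donors in the group from 1 to 0, brought no measurable gain in potency, and the true size of the step may be large or may be nothing at all.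

From the compounds shown here alone, whether any loss belongs to the ring itself or to the ethyl group on it remains open, since no piperazine with a hydrogen or a methyl in that place stands beside compound 3. Going by these compounds, how a morpholine or a plain dimethylamino group would read in this assay at this place also remains open.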